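Swapping the amide substituent: from phenylpropyl to methoxymethylpropyl

The source may hold more compounds than are shown below. What is called first, only, known or untested is meant among the compounds shown, and "the series" means these compounds.

The measured compounds:
- Compound 1, `CCCCCCCCCCCC(=O)OC[C@H](CSC[C@@H](N)C(=O)NCCO)OC(=O)CCCCCCCCCCC`: 24 nM
- Compound 2, `CCCCCCCCCCCC(=O)OC[C@H](CSC[C@@H](N)C(=O)NCCCC(C)(C)CO)OC(=O)CCCCCCCCCCC`: 30700 nM
- Compound 3, `CCCCCCCCCCCC(=O)OC[C@H](CSC[C@@H](N)C(=O)NC(C)CCc1ccccc1)OC(=O)CCCCCCCCCCC`: 160 nM

In an assay on HEK293 cells for agonist activity at Toll-like receptor 2 (Homo sapiens) (on this read-out lower numbers stand for an effect already at smaller amounts and higher numbers for an effect only at larger amounts of compound), compound 3 stands second highest of the three numbers. Its nearest neighbour is compound 1, reached through a 6.7-fold higher number from compound 1 to compound 3 (0.82 log units; beyond the scatter); the furthest is compound 2, reached through a 190-fold lower number from compound 2 to compound 3 (2.28 log units; beyond the scatter). All three share the same lipid-bearing core and differ only in the group on the amide-type nitrogen. Within this small set, the step of a 1300-fold higher number from compound 1 to compound 2 (3.11 log units; beyond the scatter) shows that a long substituent carrying a hydroxy group far from the nitrogen raises the number greatly, while compound 3 shows that a branched substituent with an aromatic ring is tolerated with a modest rise.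

Compound 4, `CCCCCCCCCCCC(=O)OC[C@H](CSC[C@@H](N)C(=O)NC(CC)COC)OC(=O)CCCCCCCCCCC`, has not been measured in this assay. It differs from compound 3 by 1-(methoxymethyl)propyl in place of 1-methyl-3-phenylpropyl on an amide-type nitrogen. The entering group is smaller than the leaving one and, like it, is branched at the carbon attached to the nitrogen; it also carries an oxygen acceptor, as compound 1 does. The bearing steps are a 6.7-fold higher number from compound 1 to compound 3 (0.82 log units; beyond the scatter) and a 190-fold lower number from compound 2 to compound 3 (2.28 log units; beyond the scatter); compound 4 is far closer in size to the substituents of compounds 1 and 3 than to that of compound 2. The step of a 1.1-fold lower number from compound 3 to compound 4 (0.03 log units; within the scatter) is therefore expected to be small, in either direction, with a number for compound 4 estimated at 150 nM in this assay, and a range from 30 nM to 1000 nM.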

Compound 4, half-maximal effective concentration: 71.8 nM
Compound 4: middle estimate off by 2.1-fold (0.32 log units), on the high side; the measured number falls inside the stated range.
By their numbers in this assay, from the lowest: compound 1; then compound 4; then compound 3; then compound 2.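

In this assay, the aromatic ring of 1-methyl-3-phenylpropyl proves dispensable on this amide-type nitrogen: the smaller, ring-free 1-(methoxymethyl)propyl gives a 2.2-fold lower number from compound 3 to compound 4 (0.35 log units; beyond the scatter) and so does slightly better than the ring-bearing group. Even so, it does not match 2-hydroxyethyl, as shown by a 3.0-fold higher number from compound 1 to compound 4 (0.48 log units; beyond the scatter) and its modest size, while it stands far from 4-(hydroxymethyl)-4-methylpentyl, as shown by a 430-fold lower number from compound 2 to compound 4 (2.63 log units; beyond the scatter) and its large size. This single change removes the ring, shortens the substituent and adds an ether oxygen all at once, and no independent measurement is available to explain the shift or divide it among these differences.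

The compounds shown leave open whether the ether oxygen matters at all, or whether a smaller branched group alone is enough; an all-carbon chain of similar length in place of 1-(methoxymethyl)propyl would test this directly. Going by these compounds, it also remains open how 1-(hydroxymethyl)propyl, with a free hydroxy in place of the methoxy, or a substituent ending in an amine or a carboxylic acid, would behave at this nitrogen.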